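Chloro to Trifluoromethyl on a Shared Triazolothiadiazine Scaffold

A few compounds are considered here, and "the series" means these few. Any claim that something is new, unique, unknown or untested is made for them only; others in the source may bear on it.

Measured compounds:
Compound 1 `CC(c1ccc(-c2ccccc2)c(F)c1)c1nnc2n1N=C(c1ccc(C(F)(F)F)cc1)CS2`: 9400 nM
Compound 2 `CC(c1ccc(-c2ccccc2)c(F)c1)c1nnc2n1N=C(c1ccc(Cl)cc1)CS2`: 3900 nM
Compound 3 `COc1ccc2cc(C(C)c3nnc4n3N=C(c3ccc(Cl)cc3)CS4)ccc2c1`: 5600 nM

In a functional assay on Huh-7 cells (Homo sapiens) for inhibition, read by sulforhodamine B assay, with a stated time of 72 h (a lower number here means a stronger inhibitor, a higher number a weaker inhibitor), compound 2 gives 3900 nM and compound 1 gives 9400 nM. The change between them, (trifluoromethyl in place of chloro on an aromatic carbon), made the step of a 2.4-fold higher number from compound 2 to compound 1 (0.38 log units; beyond the scatter). Compound 3 shares the aryl group of compound 2 but carries a different core; the difference between the two cores is not broken down here. Compound 4 `COc1ccc2cc(C(C)c3nnc4n3N=C(c3ccc(C(F)(F)F)cc3)CS4)ccc2c1` has not yet been measured. It differs from compound 3 by trifluoromethyl in place of chloro on an aromatic carbon, the same change that turned compound 2 into compound 1. On that basis compound 4 is expected to give a weaker number in this assay than compound 3, with a step of about a 2.3-fold higher number from compound 3 to compound 4 (0.37 log units; beyond the scatter), resting on the step from compound 2 to compound 1. The estimate for compound 4 is 13000 nM, between 6000 nM and 30000 nM.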

Compound 4, half-maximal inhibitory concentration: 14800 nM
Compound 4: middle estimate off by 1.1-fold (0.06 log units), on the low side; measured number inside the range.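

In this assay, trifluoromethyl in place of chloro gave a 2.6-fold higher number from compound 3 to compound 4 (0.42 log units; beyond the scatter), and the step from the first core carried over to the second: the same change on two cores in this assay, a 2.4-fold higher number (0.38 log units; beyond the scatter) from compound 2 to compound 1 and a 2.6-fold higher number (0.42 log units; beyond the scatter) from compound 3 to compound 4, 1.1-fold (0.04 log units) apart, within the scatter of two such steps

On these two cores, the change therefore moved the number in the same direction and by a matching amount. Within the data shown here, this rests on only two pairs in one assay, so it does not show that the step would hold on any other core, nor why the number rises.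

The compounds shown carry only chloro or trifluoromethyl at this place, so it remains open how a nitrile or an amine there would read. As far as these compounds go, it also remains open whether the step would persist with a carboxylic acid elsewhere on the core.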